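The compounds below may be only part of what the source reports. "The series", "measured", "known", "first", "only" and "open" are said of these compounds alone.

In a functional assay on HT-29 cells (Homo sapiens) for inhibition, with a stated time of 72 h (on this read-out lower numbers stand for stronger inhibition and higher numbers for weaker inhibition), compound 2 `COc1ccc(S(=O)(=O)N2CCc3cccc(-c4ccc(N(C)C)cc4)c32)cc1` gives 467 nM and has the highest number of the three measured, with compound 3 `COc1ccc(S(=O)(=O)n2ccc3cccc(-c4ccc(F)cc4)c32)cc1` at 196 nM and compound 1 `COc1ccc(S(=O)(=O)N2CCc3cccc(-c4ccc(F)c(F)c4)c32)cc1` at 57 nM lower. Compound 4 `COc1ccc(S(=O)(=O)N2CCc3cccc(-c4ccccc4)c32)cc1` follows from compound 2 by hydrogen in place of dimethylamino on an aromatic carbon, para to a large group. Within the data shown here, the one measured step involving the 4-(dimethylamino)phenyl group is an 8.2-fold higher number from compound 1 to compound 2 (0.91 log units; beyond the scatter) and it is modest. Among the measured compounds shown here, compound 3 has a different core and offers no direct step. Going by that step, a smaller change toward a lower number is expected in this assay here. The expected step is a 2.7-fold lower number from compound 2 to compound 4 (0.44 log units; beyond the scatter). Compound 4 is estimated at 170 nM, with an expected range from 60 nM to 400 nM.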

Compound 4, half-maximal inhibitory concentration: 96.5 nM
Beside the measured number, compound 4's estimate is 1.8-fold (0.25 log units) above it; measured number inside the range.
By their numbers in this assay, from the lowest: compounds 1 and 4 (each within the scatter of the next); then compound 3; then compound 2.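

Hydrogen in place of dimethylamino gives a 4.8-fold lower number from compound 2 to compound 4 (0.68 log units; beyond the scatter) in this assay, which gives the series an unsubstituted phenyl reference point. Against that reference, phenyl in place of 3,4-difluorophenyl gives a 1.7-fold higher number from compound 1 to compound 4 (0.23 log units; within the scatter), so the fluorines show no change beyond the scatter, and of the two substituted rings only 4-(dimethylamino)phenyl separates from phenyl. Nothing available here explains this difference.

Open, as far as these compounds go, is whether a primary amine or a methoxy group at this place would also raise the number. Also open, from the compounds shown here alone, is whether the same steps hold on the core of compound 3.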